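The source may hold more compounds than are shown below. What is called first, only, known or untested is meant among the compounds shown, and "the series" means these compounds.

Compound 1, `COc1nc(C)c(Nc2nc(Cl)cn([C@H](COC(=O)c3ccccn3)C3CC3)c2=O)cc1C`, 67 nM
Compound 2, `COc1nc(C)c(Nc2nc(Cl)cn([C@H](COC(=O)Nc3ccccc3Cl)C3CC3)c2=O)cc1C`, 1.5 nM
Compound 3, `COc1nc(C)c(Nc2nc(Cl)cn([C@H](COC(=O)Nc3ccc(Cl)cc3Cl)C3CC3)c2=O)cc1C`, 1.7 nM

The three measured compounds share a core and differ only in the group attached to the carbonyl carbon. In an assay on frontal cortex for displacement of a labelled ligand from corticotropin-releasing factor receptor 1 (Rattus norvegicus), with a stated time of 2 h (a higher number here means a weaker inhibitor, a lower number a stronger inhibitor), compound 3 gives 1.7 nM, the second highest of the three numbers; the nearest of the others lies within the scatter (a 1.1-fold higher number from compound 2 to compound 3 (0.05 log units; within the scatter)), while the furthest is well separated (a 39-fold lower number from compound 1 to compound 3 (1.60 log units; beyond the scatter)). The two steps away from the pyridin-2-yl ester are large (a 45-fold lower number from compound 1 to compound 2 (1.65 log units; beyond the scatter) and a 39-fold lower number from compound 1 to compound 3 (1.60 log units; beyond the scatter)), whereas chloro in place of hydrogen on an aromatic carbon stays within the scatter.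

Compound 4, `COc1ccc(NC(=O)OC[C@H](C2CC2)n2cc(Cl)nc(Nc3cc(C)c(OC)nc3C)c2=O)c(C)n1`, keeps the carbamate and differs from compound 3 in one place: 6-methoxy-2-methylpyridin-3-yl in place of 2,4-dichlorophenyl on an amide-type nitrogen. Among the measured compounds shown here, no measured step exchanges the aryl group of a carbamate for a heteroaryl one, so the only guidance is that both carbamates measured so far, compound 2 and compound 3, sit at the low end and that their ring substitution made no difference beyond the scatter. A step of a 1.8-fold higher number from compound 3 to compound 4 (0.25 log units; within the scatter) is therefore expected, small at most. The estimate for compound 4 in this assay is 3 nM, expected to fall between 1 nM and 12 nM.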

Compound 4, half-maximal inhibitory concentration: 9.2 nM
Estimate against measurement, compound 4: 3.1-fold (0.49 log units) below, and the stated range covers the measured number.
By their numbers in this assay, from the lowest: compounds 2 and 3 (each within the scatter of the next); then compound 4; then compound 1.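

In this assay, the group on the amide-type nitrogen proves able to move the number: a 5.4-fold higher number from compound 3 to compound 4 (0.73 log units; beyond the scatter) and a 6.1-fold higher number from compound 2 to compound 4 (0.79 log units; beyond the scatter) both lie beyond the scatter, whereas the two chlorinated phenyl carbamates had stayed within it of each other. The exchange does not erase the gain over the pyridin-2-yl ester, with a 7.3-fold lower number from compound 1 to compound 4 (0.86 log units; beyond the scatter) also beyond the scatter, so compound 4 stands in the middle of the series rather than with either end. Nothing available explains why this change raises the number.

The exchange removes the chlorine atoms and brings in the ring nitrogen, the methoxy and the methyl together, so the compounds shown do not tell which of these accounts for the step. An unsubstituted phenyl or unsubstituted pyridin-3-yl on the same nitrogen would help to separate them.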